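This account rests on a few compounds, and the source may have more. Where it says the series, first, only, none or still open, it means among the compounds named here.

Compound 1 `COc1cc(C(=O)O)ccc1OCCCCOc1ccc(C(=O)C(C)C)c(O)c1C`: in an assay on HEK293 cells for positive allosteric modulation of metabotropic glutamate receptor 3 (Rattus norvegicus), read by thallium flux, with a stated time of 2.5 min (a higher number here means that more compound is needed for the effect, a lower number that less compound is needed), compound 1 gives "not determined" (no result reported).
Compound 2 `Cc1c(OCCCCOCOc2ccc(C(=O)O)cc2)ccc(C(=O)CC2CCCC2)c1O`: in this assay compound 2 gives 1910 nM.

Compound 2 stands alone on the numbers: its value in this assay is the only one, and compound 1 has no result in this assay at all. So there is no measured step between two compounds that differ in one place, and the one recorded value carries the whole picture.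

Compound 3 `COc1ccc(C(=O)O)cc1OCCCCOc1ccc(C(=O)CC2CCCC2)c(O)c1C` is built from the same atoms as compound 2, joined differently. The change is 5-carboxy-2-methoxyphenyl in place of (4-carboxyphenoxy)methyl on an oxygen on a saturated carbon. Both groups carry one hydrogen-bond donor and two acceptors, and both hold a single six-membered aromatic ring of carbon only; what moves is where the carboxylic acid sits on that ring and how the ring is attached to the chain.

Among the measured compounds shown here, with no measured step to lean on, the expectation for compound 3 is a step of a 1.1-fold lower number from compound 2 to compound 3 (0.05 log units; within the scatter), no further than the ordinary scatter in either direction. Compound 3 is estimated at 1700 nM, within 500 nM to 6000 nM.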

Compound 3, half-maximal effective concentration: 1020 nM
Estimate against measurement, compound 3: 1.7-fold (0.22 log units) above, and the stated range covers the measured number.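

In this assay, among the compounds shown here, putting 5-carboxy-2-methoxyphenyl in place of (4-carboxyphenoxy)methyl on an oxygen on a saturated carbon gives a 1.9-fold lower number from compound 2 to compound 3 (0.27 log units; within the scatter), the only comparison available between two compounds that differ in one place. At this position, then, the same atoms can be joined differently, with the carboxylic acid moved on the ring and the ring attached to the chain in another way, and compound 2 and compound 3 still cannot be told apart in this read-out. Nothing given here offers an explanation for this result, and no independent measurement bears on it.

This single pair keeps the carboxylic acid and the aromatic ring of carbon only in both compounds, so it leaves open whether a tetrazole or an amide could stand in place of the carboxylic acid, or an amine in place of the methoxy group of the 5-carboxy-2-methoxyphenyl. It also leaves open how a longer chain would read in this assay, and whether the cyclopentyl group on the ketone side matters, since compound 1 gives "not determined" (no result reported).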